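The compounds below may be only part of what the source reports. "The series", "measured", "known", "first", "only" and "open" are said of these compounds alone.

Compound 1 `COC(=O)CC/C(C)=C/Cc1c(OC)c(C)c2c(c1OCC#CCN1CCN(c3ccc(C#N)cc3)CC1)C(=O)OC2`: > 50000 nM
Compound 2 `COC(=O)CC/C(C)=C/Cc1c(OC)c(C)c2c(c1OCC#CCN1CCN(Cc3ccc(Cl)cc3)CC1)C(=O)OC2`: > 50000 nM
Compound 3 `COC(=O)CC/C(C)=C/Cc1c(OC)c(C)c2c(c1OCC#CCN1CCN(c3ccccc3OC)CC1)C(=O)OC2`: not yet measured

In a functional assay on MDA-MB-231 cells (Homo sapiens) for inhibition, read by sulforhodamine B assay (a higher number here means a weaker inhibitor, a lower number a stronger inhibitor), compound 2 gives > 50000 nM, which is a limit and not a number. Compound 1 gives > 50000 nM, which is also a limit. Among the measured compounds shown here, the series so far therefore offers no numerical value: the limit of > 50000 nM in this assay, at which 2 of the 2 values shown sit.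

The change now in view puts 2-methoxyphenyl in place of 4-chlorobenzyl on an amine nitrogen in a ring. The hydrogen-bond acceptor counted there is the only difference in those counts.

For the measured compounds named here, one measured step bears on this, as it falls at the same place: a step that the two limits leave unreadable from compound 1 to compound 2. Its size cannot be read, so it gives no size or direction to carry over. The group entering compound 3 is a substituted phenyl, as is the 4-cyanophenyl of compound 1, which gives > 50000 nM, a limit.

No step beyond the scatter is expected in this assay, and a further limit is the likeliest report. The expected step is a number no higher from compound 2 to compound 3 (the limit leaves the size open). For compound 3 the estimated value is 50000 nM, with an expected range from 20000 nM to 100000 nM.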

Compound 3, half-maximal inhibitory concentration: > 50000 nM
Compound 3: no number, only a limit (the forecaster's own chance of this, stated with the estimate: 75%); the middle value lies on the limit itself.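

No step can be read among compound 1, compound 2 and compound 3, as each gives only a limit in this assay: the limit of > 50000 nM in this assay, at which 3 of the 3 values shown sit.

The compounds shown leave open whether any group on this amine nitrogen in a ring gives a measurable value in this assay, and how 4-cyanophenyl, 4-chlorobenzyl and 2-methoxyphenyl compare there.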